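Ester chain shortening in an acyclic adenine series

A few compounds are considered here, and "the series" means these few. Any claim that something is new, unique, unknown or untested is made for them only; others in the source may bear on it.

Compound 1 `COCCOC(=O)C(O)Cn1cnc2c(N)ncnc21` in a functional assay on Vero cells (Chlorocebus sabaeus) for cytotoxicity (on this read-out higher numbers stand for lower toxicity in this test and lower numbers for higher toxicity in this test), gives only a limit, > 400 ug/mL, so its place on the numbers is open (the limit of > 400 ug/mL in this assay, at which 1 of the 3 values shown sits). Compound 2 `CCCCOC(=O)C(O)Cn1cnc2c(N)ncnc21` in this assay gives 200 ug/mL, and compound 3 `CC(C)CCOC(=O)C(O)Cn1cnc2c(N)ncnc21` gives 400 ug/mL. The step of an at least 2.0-fold lower number from compound 1 to compound 2 (0.30 log units; that floor lies within the scatter) and the step of a 2.0-fold higher number from compound 2 to compound 3 (0.30 log units; within the scatter) both sit within the scatter, while a number no higher from compound 1 to compound 3 (the limit leaves the size open) leaves its size open. Compound 4 `COC(=O)C(O)Cn1cnc2c(N)ncnc21` differs from compound 1 by hydrogen in place of methoxymethyl on a saturated chain carbon bound to an oxygen next to a carbonyl group. Within the data shown here, no measured step removes this group; compound 2 and compound 3 are the nearest guide, and their values lie close together. A step of an at least 1.3-fold lower number from compound 1 to compound 4 (0.12 log units; that floor lies within the scatter) is expected, no larger than the scatter, with a fair chance that only a limit is reported again. Compound 4 is estimated at 300 ug/mL, between 100 ug/mL and 400 ug/mL.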

Compound 4, minimum cytotoxic concentration: > 400 ug/mL
Compound 4 gave a limit, no number (the forecaster's own chance of this, stated with the estimate: 40%); middle value at least 1.3-fold (0.12 log units) away from the limit.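

Compound 4 reads only as a limit in this assay, as compound 1 does: the limit of > 400 ug/mL in this assay, at which 2 of the 4 values shown sit. Hydrogen in place of methoxymethyl gives a step that the two limits leave unreadable from compound 1 to compound 4. Hydrogen in place of propyl gives an at least 2.0-fold higher number from compound 2 to compound 4 (0.30 log units; that floor lies within the scatter), so even the shortest ester shown stays within reach of the butyl ester of compound 2. Hydrogen in place of isobutyl gives a number no lower from compound 3 to compound 4 (the limit leaves the size open). The size of the step with methoxymethyl and of the step with isobutyl cannot be read.

On these data alone, how a carboxylic acid or a longer chain at this place would read in this assay stays open. Any real difference among compound 1, compound 3 and compound 4 also stays open.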